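The source may hold more compounds than are shown below. What is called first, only, known or untested is meant among the compounds shown, and "the series" means these compounds.

Measured in a functional assay on HeLa cells (Homo sapiens) for antiproliferative activity, read by MTT assay, with a stated time of 72 h; a higher number here means a weaker inhibitor, a lower number a stronger inhibitor:
Compound 1 `COc1ccc(N2CCN(C(=S)SCc3ccc4nc(N)nc(N)c4c3)CC2)cc1`: 1660 nM
Compound 2 `Cc1ccc(N2CCN(C(=S)SCc3ccc4nc(N)nc(N)c4c3)CC2)c(C)c1`: 3190 nM
Compound 3 `Nc1nc(N)c2cc(CSC(=S)N3CCN(c4ccc(Cl)c(Cl)c4)CC3)ccc2n1`: 3060 nM

These three compounds share a core and differ only in the group on an amine nitrogen in a ring. On the numbers in this assay, compound 3 stands within the scatter of both other compounds. The account now turns to compound 4 `Nc1nc(N)c2cc(CSC(=S)N3CCN(c4ccc(F)cc4)CC3)ccc2n1`, which has not yet been measured. It carries 4-fluorophenyl in place of the 3,4-dichlorophenyl of compound 3: 4-fluorophenyl in place of 3,4-dichlorophenyl on an amine nitrogen in a ring.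

The three measured steps all change this same group, so all three bear on the new change. They are a 1.0-fold lower number from compound 2 to compound 3 (0.02 log units; within the scatter), a 1.8-fold higher number from compound 1 to compound 3 (0.27 log units; within the scatter) and a 1.9-fold higher number from compound 1 to compound 2 (0.28 log units; within the scatter). Each lies within the scatter, even though 4-methoxyphenyl, 2,4-dimethylphenyl and 3,4-dichlorophenyl all differ from one another. Among the compounds with values here, none of the measured compounds carries 4-fluorophenyl, so the data give no direct reading of this group, and the expectation rests on the small size of those steps. No step beyond the scatter is expected in this assay, and no firm direction can be assigned.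

The estimated step is a 1.3-fold lower number from compound 3 to compound 4 (0.11 log units; within the scatter). For compound 4 the estimated value is 2400 nM, with an expected range from 1100 nM to 5200 nM.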

Compound 4, half-maximal inhibitory concentration: 1840 nM
Compound 4: the middle estimate sits 1.3-fold (0.12 log units) above what was measured; the range from low to high includes it.
By their numbers in this assay, from the lowest: compounds 1, 4, 3 and 2 (each within the scatter of the next).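

In this assay, a fourth substituted phenyl group on the amine nitrogen in the ring leaves the number within the scatter, with a 1.7-fold lower number from compound 3 to compound 4 (0.22 log units; within the scatter) and a 1.7-fold lower number from compound 2 to compound 4 (0.24 log units; within the scatter). Within the data shown here, the comparison with compound 1 adds the narrowest change so far, fluoro in place of methoxy on an aromatic carbon, and it gives a 1.1-fold higher number from compound 1 to compound 4 (0.04 log units; within the scatter), so the insensitivity seen among the earlier compounds now extends to a group carrying a single fluorine and to a one-substituent exchange on the same ring. No measurement shown here accounts for how little these four groups separate.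

All four compounds carry a substituted phenyl on this nitrogen, so the compounds shown leave open whether an unsubstituted phenyl, a pyridine, a benzyl group or a simple alkyl chain there would also stay within the scatter in this assay. They also leave open whether a carbonyl in place of the thiocarbonyl in the link to the shared core would move the number further than any of these changes on the ring nitrogen.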